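Dropping One Hydroxy Group: From Compound 3 to Compound 4

The source may report more compounds than this note shows. Statements on the series, on what has been measured and on what is new or still open speak of the compounds shown alone.

Of the compounds shown here, three built on one shared core have been measured in a functional assay, with a stated time of 30 min; a higher number here means a weaker inhibitor, a lower number a stronger inhibitor. Compound 1 `CCOc1ccc(/C=N/n2c(S)nnc2-c2cnccn2)cc1OC` gives 58800 nM in this assay. Compound 2 `CN(C)c1ccc(/C=N/n2c(S)nnc2-c2cnccn2)cc1` gives 14000 nM. Compound 3 `Oc1ccc(/C=N/n2c(S)nnc2-c2cnccn2)c(O)c1` gives 75900 nM, the highest of the three numbers; its nearest neighbour is compound 1, whose number lies within the scatter of it, while compound 2 stands beyond the scatter with a lower number.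

Compound 4 `Oc1ccc(/C=N/n2c(S)nnc2-c2cnccn2)cc1` has not yet been measured in this assay. It differs from compound 3 in one place: hydrogen in place of hydroxy on an aromatic carbon. Within the data shown here, no step between two measured compounds matches this change, so the measured set gives no direct guide to the size of the move.

What the measured compounds do show is that compound 3 gives 75900 nM while compound 1, which carries no hydroxy group at all, lies within the scatter of it, so no large shift is expected from removing one hydroxy group. For compound 4 the estimate is 50000 nM, with a range from 15000 nM to 150000 nM. The expected step, a 1.5-fold lower number from compound 3 to compound 4 (0.18 log units; within the scatter), is a small one towards a lower number and not clearly beyond the scatter.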

Compound 4, half-maximal inhibitory concentration: 58900 nM
Compound 4: the middle estimate sits 1.2-fold (0.07 log units) below what was measured; measured number inside the range.
By their numbers in this assay, from the lowest: compound 2; then compounds 1, 4 and 3 (each within the scatter of the next).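

In this assay, hydrogen in place of hydroxy on the aromatic carbon ortho to a large group and meta to a hydroxy group gives a 1.3-fold lower number from compound 3 to compound 4 (0.11 log units; within the scatter), so this hydroxy group can be lost without the number leaving the scatter. Hydroxy in place of dimethylamino on an aromatic carbon gives a 4.2-fold higher number from compound 2 to compound 4 (0.62 log units; beyond the scatter), which is beyond the scatter and shows that a one-place change on this ring can shift the number, though the loss of hydroxy did not. No other measurement bears on why these two steps differ in size.

Only hydroxy and hydrogen are shown on the carbon that changed here, so it remains open whether an amine or a carboxylic acid on that carbon would also stay within the scatter of compound 4. As far as these compounds go, it also remains open how far the step between dimethylamino and hydroxy extends, for instance whether diethylamino, with its longer chains, would give a number in line with compound 2 or with compound 4.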